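Butyl in Place of Chloro on the Distal Ring

The compounds below may be only part of what the source reports. "The series", "measured", "known", "first", "only" and "open" are said of these compounds alone.

Three compounds share one core and differ only in where a chlorine sits on the outer ring. In an assay on mitochondria (strain BALB/c) for inhibition of glycerol-3-phosphate acyltransferase 1, mitochondrial (Mus musculus), read by scintillation counting, with a stated time of 10 min (on this read-out lower numbers stand for stronger inhibition and higher numbers for weaker inhibition), compound 1 `CCCCCCCCS(=O)(=O)Nc1ccc(-c2ccccc2Cl)cc1C(=O)O` gives 14400 nM, compound 2 `CCCCCCCCS(=O)(=O)Nc1ccc(-c2cccc(Cl)c2)cc1C(=O)O` gives 8900 nM, and compound 3 `CCCCCCCCS(=O)(=O)Nc1ccc(-c2ccc(Cl)cc2)cc1C(=O)O` gives 9200 nM. The steps of a 1.6-fold lower number from compound 1 to compound 2 (0.21 log units; within the scatter), a 1.6-fold lower number from compound 1 to compound 3 (0.19 log units; within the scatter) and a 1.0-fold higher number from compound 2 to compound 3 (0.01 log units; within the scatter) all lie within the scatter, so compound 3 stands level with the other two. Compound 4 `CCCCCCCCS(=O)(=O)Nc1ccc(-c2ccc(CCCC)cc2)cc1C(=O)O` carries butyl in place of chloro on an aromatic carbon. Among the compounds with values here, no measured step exchanges the chloro for a carbon chain, so the three chlorine moves give no direct guide; they only show that this position tolerates change without a shift beyond the scatter. Compound 4 is therefore expected to give 6000 nM (range 1500 nM to 25000 nM), an estimated step of a 1.5-fold lower number from compound 3 to compound 4 (0.19 log units; within the scatter).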

Compound 4, half-maximal inhibitory concentration: 9000 nM
Estimate against measurement, compound 4: 1.5-fold (0.18 log units) below; measured number inside the range.
By their numbers in this assay, from the lowest: compounds 2, 4, 3 and 1 (each within the scatter of the next).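

In this assay, the larger butyl on this aromatic carbon stands level with chloro (a 1.0-fold lower number from compound 3 to compound 4 (0.01 log units; within the scatter)), so this position takes a carbon chain as well as a chlorine. Compound 4 also stands level with both other chlorine placements (a 1.0-fold higher number from compound 2 to compound 4 (0.00 log units; within the scatter); a 1.6-fold lower number from compound 1 to compound 4 (0.20 log units; within the scatter)). No measurement offered here accounts for this result. Open, on these data alone, is whether an amine or a carboxylic acid at this position would stay level with butyl. Also open, as far as these compounds go, is whether a chain longer than butyl would do so.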